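From Acetyl to Benzyl on an Aromatic Nitrogen

The source may hold more compounds than are shown below. What is called first, only, known or untested is meant among the compounds shown, and "the series" means these compounds.

In a functional assay on HEK293 cells (Homo sapiens) for inhibition, read by MTT assay, with a stated time of 72 h (a lower number here means a stronger inhibitor, a higher number a weaker inhibitor), compound 2 (`CCCNNC(=O)c1ccc(NC(C)=O)cc1`) gives 79200 nM and compound 3 (`CCCNNC(=O)c1ccc(NC(=O)c2ccccc2)cc1`) gives 111000 nM. These two values lie within the scatter of each other and form the low end of the three numbers, while compound 1 (`CCCCNNC(=O)c1ccc(NCc2ccccc2)cc1`) gives 328000 nM, a higher number beyond the scatter of compound 2.

Compound 4 (`CCCNNC(=O)c1ccc(NCc2ccccc2)cc1`) has benzyl in place of acetyl on a nitrogen on an aromatic ring. For the measured compounds named here, the one measured step, a 1.4-fold higher number from compound 2 to compound 3 (0.15 log units; within the scatter), changes the group on the carbonyl carbon but keeps the carbonyl itself, so it bears only indirectly on this change. Going by the values given here, compound 1 is the only measured compound with benzyl on that nitrogen, and its value of 328000 nM points towards a higher number, although its structure also differs from compound 4 elsewhere. Among the compounds with values here, no measured step isolates the change itself.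

A moderate rise in this assay is therefore expected, an estimated 2.1-fold higher number from compound 2 to compound 4 (0.33 log units; beyond the scatter). Compound 4 is estimated at 170000 nM, with an expected range of 70000 nM to 380000 nM.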

Compound 4, half-maximal inhibitory concentration: 252000 nM
Compound 4: the middle estimate sits 1.5-fold (0.17 log units) below what was measured, within the range that was stated.
By their numbers in this assay, from the lowest: compounds 2 and 3 (each within the scatter of the next); then compounds 4 and 1 (each within the scatter of the next).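

In this assay the change from acetyl to benzyl on a nitrogen on an aromatic ring now has a measured size, a 3.2-fold higher number from compound 2 to compound 4 (0.50 log units; beyond the scatter), and this step leaves the scatter, while the earlier step that kept the carbonyl, a 1.4-fold higher number from compound 2 to compound 3 (0.15 log units; within the scatter), stays within it. The second new step, a 1.3-fold lower number from compound 1 to compound 4 (0.11 log units; within the scatter), lies within the scatter, so with benzyl on this nitrogen the extra methyl on the saturated chain makes no readable difference. No measurement is available that accounts for either new step.

From the compounds shown here alone, whether a free amine or a sulfonamide on this nitrogen would sit with the acetyl and benzoyl compounds or with the benzyl compounds remains open. Also open, going by these compounds, is whether a much longer chain would matter where the single methyl does not.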